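Bromo to fluoro exchange on the phenylamino group

The compounds below may be only part of what the source reports. "The series", "measured", "known", "first", "only" and "open" are said of these compounds alone.

Compound 2 `Cc1cc(Nc2ccc(Br)cc2)nc(SCc2nc3ccccc3[nH]2)n1` gives 38000 nM in a functional assay on MCF7 cells (Homo sapiens) for cytotoxicity, read by MTT assay, with a stated time of 72 h; a lower number here means a stronger inhibitor, a higher number a weaker inhibitor; compound 1 `COc1ccc(Nc2cc(C)nc(SCc3nc4ccccc4[nH]3)n2)cc1` gives 61100 nM in this assay. Compound 2 holds the lower of the two numbers, yet the step of a 1.6-fold lower number from compound 1 to compound 2 (0.21 log units; within the scatter) lies within the scatter, so the two compounds cannot be set in order. Compound 3 `Cc1cc(Nc2ccc(F)cc2)nc(SCc2nc3ccccc3[nH]2)n1` is not yet measured; it differs from compound 2 by fluoro in place of bromo on an aromatic carbon. Among the compounds with values here, no measured step exchanges one halogen for another; the only step at the same place, a 1.6-fold lower number from compound 1 to compound 2 (0.21 log units; within the scatter), puts bromo in place of methoxy and stays within the scatter. Within the data shown here, a halogen exchange has no precedent, and the expected step of a 1.3-fold higher number from compound 2 to compound 3 (0.12 log units; within the scatter) is therefore none beyond the scatter, with a wide band around it. Compound 3 is estimated at 50000 nM in this assay, with a range from 20000 nM to 120000 nM.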

Compound 3, half-maximal inhibitory concentration: 42200 nM
Estimate against measurement, compound 3: 1.2-fold (0.07 log units) above; the range from low to high includes it.
By their numbers in this assay, from the lowest: compounds 2, 3 and 1 (each within the scatter of the next).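

In this assay, within the data shown here, the first halogen exchange at this place gives a 1.1-fold higher number from compound 2 to compound 3 (0.05 log units; within the scatter) and so does not separate fluoro from bromo. Methoxy and fluoro, compared directly, give a 1.4-fold lower number from compound 1 to compound 3 (0.16 log units; within the scatter) and also cannot be set in order, so all three groups on the aromatic carbon now stand within the scatter of one another, whereas the earlier pair covered only two groups. No measurement on hand explains this flat result at the position. On these data alone, whether an amine, a carboxylic acid or a longer chain such as butoxy at this place would give a step beyond the scatter remains open. All three compounds also share the rest of the core unchanged, so the effect of a change elsewhere on the molecule is open too.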